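Replacing the Pyridine Carboxamide Group of Compound 2

The source may report more compounds than this note shows. Statements on the series, on what has been measured and on what is new or still open speak of the compounds shown alone.

Among the compounds with values here, in an assay (Rattus norvegicus) for inhibition of Fatty-acid amide hydrolase 1 (Homo sapiens) (on this read-out lower numbers stand for stronger inhibition and higher numbers for weaker inhibition), compound 2 `NC(=O)c1ccc(-c2cnc(C(=O)CCCCCCc3ccccc3)o2)nc1` gives 1.2 nM, the lowest of the two numbers measured so far; compound 1 `O=C(CCCCCCc1ccccc1)c1ncc(-c2ccccc2F)o1` gives 110 nM. Compound 3 `O=C(CCCCCCc1ccccc1)c1ncc(-c2cc(=O)[nH]c(=O)[nH]2)o1` carries the change (a group of 8 heavy atoms (4 carbon, 2 nitrogen, 2 oxygen; one six-membered aromatic ring with 2 hetero atoms) in place of a group of 9 heavy atoms (6 carbon, 2 nitrogen, 1 oxygen; one six-membered aromatic ring with 1 hetero atom), on an aromatic carbon). Within the data shown here, the only measured step at this aromatic carbon, a 92-fold lower number from compound 1 to compound 2 (1.96 log units; beyond the scatter), shows that the group attached here can move the number a great deal. Among the measured compounds shown here, no measured step includes the entering group, so its direction is uncertain, and a partial return toward the level of compound 1 cannot be excluded. Compound 3 is expected to give 8 nM, within a range of 1.5 nM to 50 nM, which means an estimated step of a 6.7-fold higher number from compound 2 to compound 3 (0.82 log units; beyond the scatter).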

Compound 3, inhibition constant: 12 nM
Compound 3: middle estimate off by 1.5-fold (0.18 log units), on the low side; the range from low to high includes it.
By their numbers in this assay, from the lowest: compound 2; then compound 3; then compound 1.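

Within the data shown here, a pyridine carboxamide is not the only group at this aromatic carbon that gives a low number: the entering six-membered ring with 2 hetero atoms stays well ahead of 2-fluorophenyl (a 9.2-fold lower number from compound 1 to compound 3 (0.96 log units; beyond the scatter)). It still falls short of 5-carbamoylpyridin-2-yl (a 10-fold higher number from compound 2 to compound 3 (1.00 log units; beyond the scatter)), so the choice of ring and its substituents matters here. No available evidence explains either step.

As far as these compounds go, whether a carboxylic acid in place of the carboxamide on the pyridine ring, or a carboxamide on a plain benzene ring, would match compound 2 remains open.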